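Oxetane in place of isobutyl on the triazole nitrogen

This account rests on a few compounds, and the source may have more. Where it says the series, first, only, none or still open, it means among the compounds named here.

Measured so far in a functional assay on HT-29 cells (Homo sapiens) for inhibition, read by luminescence and CellTiter-Glo, with a stated time of 24 h; on this read-out lower numbers stand for an effect already at smaller amounts and higher numbers for an effect only at larger amounts of compound:
- compound 1 `CN1C(=S)[C@@H](NC(=O)c2nc(Cc3ccccc3)n(C)n2)COc2ccccc21` gives 2.5 nM
- compound 2 `CCn1nc(C(=O)N[C@H]2COc3ccccc3N(C)C2=S)nc1Cc1ccccc1` gives 17 nM
- compound 3 `CC(C)CCn1nc(C(=O)N[C@H]2COc3ccccc3N(C)C2=S)nc1Cc1ccccc1` gives 3640 nM

Compound 3 stands at the top of these three numbers: the step of a 210-fold higher number from compound 2 to compound 3 (2.33 log units; beyond the scatter) and the step of a 1500-fold higher number from compound 1 to compound 3 (3.16 log units; beyond the scatter) both lie well beyond the scatter, so compound 3 is the least potent of the measured set in this assay. The trio traces a single line of change at one spot of the shared core: hydrogen, then methyl, then isobutyl on a saturated chain carbon bound to an aromatic nitrogen, and each enlargement raised the number, by a 6.8-fold higher number from compound 1 to compound 2 (0.83 log units; beyond the scatter) and then by a 210-fold higher number from compound 2 to compound 3 (2.33 log units; beyond the scatter).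

Compound 4 `CN1C(=S)[C@@H](NC(=O)c2nc(Cc3ccccc3)n(CC3COC3)n2)COc2ccccc21` keeps the size of the group at that spot but changes its kind: oxetan-3-yl in place of isobutyl on a saturated chain carbon bound to an aromatic nitrogen. The oxetan-3-yl ring carries as many heavy atoms as the isobutyl it replaces, so the steps above, which all concern growth at this position, suggest the number will stay high rather than fall back toward compound 1. For the measured compounds named here, no measured pair shows what an oxygen-containing ring does here, so the direction of any shift is open; a step of a 1.8-fold lower number from compound 3 to compound 4 (0.26 log units; within the scatter) is expected, within the scatter. Compound 4 is therefore estimated at 2000 nM in this assay, with a range from 400 nM to 10000 nM.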

Compound 4, half-maximal effective concentration: 2830 nM
Compound 4: middle estimate off by 1.4-fold (0.15 log units), on the low side, and the stated range covers the measured number.
By their numbers in this assay, from the lowest: compound 1; then compound 2; then compounds 4 and 3 (each within the scatter of the next).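

In this assay the exchange of isobutyl for oxetan-3-yl on a saturated chain carbon bound to an aromatic nitrogen brings in an oxygen, a four-membered ring and a hydrogen-bond acceptor at the same count of heavy atoms, yet the result is only a 1.3-fold lower number from compound 3 to compound 4 (0.11 log units; within the scatter), so this read-out does not tell the two groups apart. Both groups remain far from the smaller ones: oxetan-3-yl in place of methyl gives a 170-fold higher number from compound 2 to compound 4 (2.22 log units; beyond the scatter), and oxetan-3-yl in place of hydrogen gives a 1100-fold higher number from compound 1 to compound 4 (3.05 log units; beyond the scatter), so among these four compounds the change in the kind of group recovers none of the ground lost as the group grew. No measured property is available to explain why the oxygen and the ring leave no visible mark on the number.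

The compounds shown leave open where between methyl and isobutyl the number begins its climb, which a propyl chain at this position could help to show. They also leave open whether a group of similar size carrying an amine or a carboxylic acid would behave like oxetan-3-yl.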